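The source may report more compounds than this note shows. Statements on the series, on what has been measured and on what is new or still open speak of the compounds shown alone.

Working notes on the series.

Three compounds share one core and differ only in the aryl group on a saturated chain carbon bound to an amine nitrogen. Compound 1 `CC(C)(C)c1ccc(CNCCNS(=O)(=O)c2cc(C(F)(F)F)cc(C(F)(F)F)c2)cc1` carries a two-carbon link and in a functional assay on Capan-2 cells (Homo sapiens) for inhibition, read by MTT assay, with a stated time of 72 h (a lower number here means a stronger inhibitor of growth, a higher number a weaker inhibitor of growth), compound 1 gives 13000 nM. Compound 2 `CC(C)(C)c1ccc(CNCCCNS(=O)(=O)c2cc(C(F)(F)F)cc(C(F)(F)F)c2)cc1` has the three-carbon link and in this assay compound 2 gives 2100 nM. Compound 3 `COc1cccc(CNCCCNS(=O)(=O)c2cc(C(F)(F)F)cc(C(F)(F)F)c2)c1` keeps that link and in this assay compound 3 gives 6400 nM, which places compound 3 second highest of the three numbers, nearest to compound 1 and furthest from compound 2. Going by the values given here, the only step at the aryl position is a 3.0-fold higher number from compound 2 to compound 3 (0.48 log units; beyond the scatter).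

Compound 4 `O=S(=O)(NCCCNCc1ccccc1Cl)c1cc(C(F)(F)F)cc(C(F)(F)F)c1` is not yet measured. Its change from compound 3 is 2-chlorophenyl in place of 3-methoxyphenyl on a saturated chain carbon bound to an amine nitrogen. Among the compounds with values here, only the step from compound 2 to compound 3 bears on this change, since it is the one exchange of the aryl group with a fixed three-carbon link, and it was modest. Within the data shown here, no measured pair shows the chlorinated group itself, so the direction is open; a step of about that size or smaller, in either direction, is the expectation for this assay.

Compound 4 is estimated at 4500 nM, in the range 1500 nM to 15000 nM, which means an expected step of a 1.4-fold lower number from compound 3 to compound 4 (0.15 log units; within the scatter).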

Compound 4, concentration for 50% growth inhibition: 13000 nM
Beside the measured number, compound 4's estimate is 2.9-fold (0.46 log units) below it, within the range that was stated.
By their numbers in this assay, from the lowest: compound 2; then compound 3; then compounds 1 and 4 (each within the scatter of the next).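

With the link unchanged, 2-chlorophenyl in place of 3-methoxyphenyl gives a 2.0-fold higher number from compound 3 to compound 4 (0.31 log units; beyond the scatter) in this assay, so the direction left open at this position is now settled for this one change. Against 4-(tert-butyl)phenyl, the same group gives a 6.2-fold higher number from compound 2 to compound 4 (0.79 log units; beyond the scatter), the largest step so far among the aryl exchanges, and all three groups on this link now stand apart beyond the scatter, from 4-(tert-butyl)phenyl at the lowest number through 3-methoxyphenyl to 2-chlorophenyl at the highest. Nothing available accounts for this order, and it rests on these three compounds alone.

Each of the three aryl groups differs from the others in both the substituent and its place on the ring, so the contribution of each remains unseparated, and an unsubstituted phenyl group would give the missing reference for all three. On these data alone, whether the order of the aryl groups holds on a longer chain also remains open, as does whether a bromine or a second chlorine at this position would follow 2-chlorophenyl in this assay.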